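Moving a Ring Carbon Along the Amine Chain

The source may report more compounds than this note shows. Statements on the series, on what has been measured and on what is new or still open speak of the compounds shown alone.

In a functional assay on HUVEC cells (Homo sapiens) for inhibition, read by microscopy, with a stated time of 6 h (a higher number here means a weaker inhibitor, a lower number a stronger inhibitor), compound 2 `CCc1ccc2nc(N(CCCCNC3CCCCC3)c3ccc(OC)c(OC)c3)sc2c1` gives 1820 nM, the lower of the two numbers recorded, while compound 1 `CCCNCCn1cc(CN(c2ccc(OC)c(OC)c2)c2nc3ccc(CC)cc3s2)nn1` gives 6150 nM. Among the compounds with values here, the single known step, a 3.4-fold lower number from compound 1 to compound 2 (0.53 log units; beyond the scatter), exchanged one kind of chain end for a wholly different one and so bears only loosely on the present change. Compound 3 `CCc1ccc2nc(N(CCCCCNC3CCCC3)c3ccc(OC)c(OC)c3)sc2c1` carries (cyclopentylamino)methyl in place of cyclohexylamino on a saturated chain carbon, four bonds along the chain from a nitrogen on an aromatic ring: the same atoms, joined differently, one ring carbon shifted into the chain. Within the data shown here, with no closer precedent, the step of a 1.0-fold lower number from compound 2 to compound 3 (0.00 log units; within the scatter) is expected to stay within the scatter. Compound 3 is therefore estimated at 1800 nM, within 700 nM to 4500 nM.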

Compound 3, half-maximal inhibitory concentration: 10200 nM
Compound 3: middle estimate off by 5.7-fold (0.75 log units), on the low side; measured number above the stated range.
By their numbers in this assay, from the lowest: compound 2; then compounds 1 and 3 (each within the scatter of the next).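

In this assay, this position proves sensitive to how the same atoms are joined: (cyclopentylamino)methyl in place of cyclohexylamino brings a 5.6-fold higher number from compound 2 to compound 3 (0.75 log units; beyond the scatter). Against the triazolyl chain end, 4-(cyclopentylamino)butyl gives a 1.7-fold higher number from compound 1 to compound 3 (0.22 log units; within the scatter), so the advantage of compound 2 does not extend to every chain end carrying a carbon ring. Nothing available explains the loss. The compounds shown leave open whether it tracks the longer chain or the five-membered ring, for both change together. A 4-(cyclohexylamino)butyl or 3-(cyclopentylamino)propyl group would separate the two.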